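The source may report more compounds than this note shows. Statements on the series, on what has been measured and on what is new or still open speak of the compounds shown alone.

Measured so far:
- compound 1 `CC(=O)NC[C@H]1CN(c2ccc(N3CCN(c4nnc(-c5ccc([N+](=O)[O-])s5)s4)CC3)c(F)c2)C(=O)O1`, in an ADME assay on NIH3T3 cells (Mus musculus) for cytotoxicity, read by colorimetric assay and MTT assay (on this read-out higher numbers stand for weaker inhibition and lower numbers for stronger inhibition), compound 1 gives 184 ug/mL.
- compound 2 `CC(=O)NC[C@H]1CN(c2ccc(N3CCN(c4nnc(-c5ccc([N+](=O)[O-])o5)s4)CC3)c(F)c2)C(=O)O1`, in this assay compound 2 gives 21.8 ug/mL.

Among the measured compounds shown here, compound 2 stands at the lowest of the two numbers in this assay; the only neighbour is compound 1, and the step is an 8.4-fold lower number from compound 1 to compound 2 (0.93 log units; beyond the scatter).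

Compound 3 `CC(=O)NC[C@H]1CN(c2ccc(N3CCN(c4nnc(-c5ncc([N+](=O)[O-])n5C)s4)CC3)c(F)c2)C(=O)O1` differs from compound 2 at one place: 1-methyl-5-nitro-1H-imidazol-2-yl in place of 5-nitrofuran-2-yl on an aromatic carbon. For the measured compounds named here, no measured pair shows this exact exchange. Going by the values given here, the one step that bears on it, an 8.4-fold lower number from compound 1 to compound 2 (0.93 log units; beyond the scatter), shows that swapping the nitro-bearing five-membered aromatic ring at this position can move the number well beyond the scatter in either sense, but it does not indicate which way a 1-methyl-5-nitro-1H-imidazol-2-yl would go. The outcome in this assay is therefore held open, with a step of a 2.8-fold higher number from compound 2 to compound 3 (0.44 log units; beyond the scatter) expected as a central guess and a wide range around it.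

For compound 3 the expected value in this assay is 60 ug/mL, with a range from 15 ug/mL to 250 ug/mL.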

Compound 3, half-maximal inhibitory concentration: > 200 ug/mL
Compound 3: no number, only a limit; the forecaster's own chance of this, stated with the estimate: 10%; at least 3.3-fold (0.52 log units) between middle value and limit.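

In this assay compound 3 is read only against a limit of the assay, not as a number: the limit of > 200 ug/mL in this assay, at which 1 of the 3 values shown sits. On this aromatic carbon, 1-methyl-5-nitro-1H-imidazol-2-yl in place of 5-nitrofuran-2-yl gives an at least 9.1-fold higher number from compound 2 to compound 3 (0.96 log units; beyond the scatter), so the new ring, with its 2 hetero atoms, settles the direction left open earlier, while the size of the step remains only a floor. The other exchange, 1-methyl-5-nitro-1H-imidazol-2-yl in place of 5-nitrothiophen-2-yl, sets no order between its two compounds, an at least 1.0-fold higher number from compound 1 to compound 3 (0.03 log units; that floor lies within the scatter), so among these three nitro-bearing rings only the 5-nitrofuran-2-yl of compound 2 stands apart, with its steps to both neighbours beyond the scatter.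

On these data alone, the imidazole exchange changes the ring and adds the methyl on the ring nitrogen at once, so the share of each in the step stays open, as would be tested by the same ring with hydrogen or a longer chain such as ethyl on that nitrogen. Also open, as far as these compounds go, is whether the number of compound 2 would hold with an amine or a nitrile in place of the nitro group on the furan ring.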